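Carboxy in place of hydroxy: working notes

This account rests on a few compounds, and the source may have more. Where it says the series, first, only, none or still open, it means among the compounds named here.

Compound 1 `Cc1nc2sc(-c3ccccc3)nc2c(=O)[nH]1` and compound 2 `Cc1nc2sc(-c3ccc(O)cc3)nc2c(=O)[nH]1` share one core and differ at a single aromatic carbon, where compound 2 carries hydroxy. In an assay on CHO cells for displacement of a labelled ligand from adenosine receptor A1 (Homo sapiens), read by scintillation counting, with a stated time of 120 min, tested at 1 uM (on this read-out higher numbers stand for more inhibition at the one concentration tested (going by the name of the read-out) and lower numbers for less inhibition), compound 1 gives 11% and compound 2 gives 1%; the step of a number 10 percentage points lower from compound 1 to compound 2 (within the scatter) lies within the scatter. Compound 2 thus holds the lowest of the two numbers on paper, with compound 1 nearest and within the scatter, so the two are not distinguishable. Compound 3 `Cc1nc2sc(-c3ccc(C(=O)O)cc3)nc2c(=O)[nH]1` is not yet measured and differs from compound 2 by carboxy in place of hydroxy on an aromatic carbon. Within the data shown here, only one measured step bears on this change, a number 10 percentage points lower from compound 1 to compound 2 (within the scatter), and it was within the scatter; no step from hydroxy to carboxy has been measured, and both known numbers sit near the bottom of the scale. A step of a number 4 percentage points higher from compound 2 to compound 3 (within the scatter) is therefore expected, none beyond the scatter. Compound 3 is estimated at 5%, between -10% and 25%.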

Compound 3, a percentage reported as inhibition, at one concentration (the size of the read-out at that concentration, not a potency): 1%
Compound 3: the middle estimate sits 4 percentage points above what was measured, within the range that was stated.
By their numbers in this assay, from the lowest: compounds 2, 3 and 1 (each within the scatter of the next).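

Carboxy now joins hydroxy at the same aromatic carbon, para to a large group, and in this assay the exchange of hydroxy for carboxy gives (no change at the digits printed from compound 2 to compound 3 (within the scatter)), while carboxy in place of hydrogen gives (a number 10 percentage points lower from compound 1 to compound 3 (within the scatter)). Hydrogen, hydroxy and carboxy at this position therefore cannot be told apart on this read-out, and the larger carboxy group, with its three heavy atoms, does not lift the number beyond the scatter. No measurement available here offers an explanation for this flat result.

As far as these compounds go, whether an amine, a methoxy group or a longer chain at this position would give a number beyond the scatter remains open. Also open, from the compounds shown here alone, is whether a change elsewhere on the shared core would do so.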